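The source may report more compounds than this note shows. Statements on the series, on what has been measured and on what is new or still open speak of the compounds shown alone.

The measured compounds and their values:

compound 1 `CC(=O)c1cccc(-c2ccc(C(=O)N(Cc3cccc(OCCCCCC(=O)O)c3)C(C)C)cc2)c1` — > 26000 nM
compound 2 `CC(C)COc1cccc(-c2ccc(C(=O)N(Cc3cccc(OCCCCCC(=O)O)c3)C(C)C)cc2)c1` — > 26000 nM
compound 3 `CCOC(=O)CCCCCOc1cccc(CN(C(=O)c2ccc(-c3cccc(C(C)=O)c3)cc2)C(C)C)c1` — > 26000 nM

All three were tested in an ADME assay on Raji cells (Homo sapiens) for cytotoxicity, read by CellTiter-Glo and resazurin assay, with a stated time of 72 h; on this read-out higher numbers stand for an effect only at larger amounts of compound and lower numbers for an effect already at smaller amounts. In this assay compound 1 gives > 26000 nM, a limit of the assay rather than a number. Compound 2 likewise reaches only the limit > 26000 nM. Compound 3 also stops at the limit > 26000 nM. Compound 2 differs from compound 1 by isobutoxy in place of acetyl on an aromatic carbon, and the step that the two limits leave unreadable from compound 1 to compound 2 cannot be read, since both values sit at the limit of > 26000 nM in this assay, at which 3 of the 3 values shown sit. Compound 3 differs from compound 1 by ethyl in place of hydrogen on an oxygen next to a carbonyl group, and the step that the two limits leave unreadable from compound 1 to compound 3 is equally unreadable for the same reason, (the limit of > 26000 nM in this assay, at which 3 of the 3 values shown sit).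

Compound 4 `CCOC(=O)CCCCCOc1cccc(CN(C(=O)c2ccc(-c3cccc(OCC(C)C)c3)cc2)C(C)C)c1` has not been measured. It differs from compound 3 by isobutoxy in place of acetyl on an aromatic carbon, the same change as from compound 1 to compound 2, on a core that differs by ethyl in place of hydrogen on an oxygen next to a carbonyl group. Since compound 1 and compound 2 both sit at the limit of > 26000 nM in this assay, at which 3 of the 3 values shown sit, the step that the limit leaves unreadable from compound 3 to compound 4 is expected to be small. Compound 4 is therefore expected to give roughly 40000 nM, most likely again only a limit, somewhere between 20000 nM and 120000 nM.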

Compound 4, half-maximal effective concentration: > 26000 nM
Compound 4 ended at the assay's limit; the forecaster's own chance of this, stated with the estimate: 85%; the middle value is on the limit's open side.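

No new step can be read between compounds 2, 3 and 4, because compound 4 stops at the same limit as the others, which is not a number: the limit of > 26000 nM in this assay, at which 4 of the 4 values shown sit.

The compounds shown leave open where the true value of each one lies in this assay, and so whether either change alters it at all.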